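The compounds below may be only part of what the source reports. "The series", "measured", "known", "first", "only" and "open" are said of these compounds alone.

Compound 1 `COc1cccc(CNCCCNc2ccnc3cc(Cc4ccc(C#N)cc4)ccc23)c1O` has been tested in an ADME assay on HepG2 cells (Homo sapiens) for cytotoxicity, read by luminescence, CellTiter-Glo and ATP content, with a stated time of 72 h (a lower number here means that less compound is needed, a higher number that more compound is needed for the effect), where compound 1 gives 7150 nM. For the measured compounds named here, of the two numbers known so far this is the lowest; its nearest neighbour is compound 2 `N#Cc1ccc(Cc2ccc3c(NCCCNCc4ccco4)ccnc3c2)cc1`, which in this assay gives 7910 nM, and the step of a 1.1-fold higher number from compound 1 to compound 2 (0.04 log units; within the scatter) falls within the scatter. Compound 3 `COc1cccc(CNCCCNc2ccnc3cc(C4CCCCC4)ccc23)c1O` has not yet been measured. It differs from compound 1 in one place: cyclohexyl in place of 4-cyanobenzyl on an aromatic carbon. Going by the values given here, the only measured step exchanges furan-2-yl for 2-hydroxy-3-methoxyphenyl on a saturated chain carbon bound to an amine nitrogen, a change at another part of the shared core, so no measured step bears directly on an exchange at this aromatic carbon. With nothing to point either way, the expected step is a 1.0-fold higher number from compound 1 to compound 3 (0.02 log units; within the scatter), that is, no change beyond the scatter. Compound 3 is therefore estimated at 7500 nM, with a range from 3000 nM to 20000 nM.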

Compound 3, half-maximal effective concentration: 1080 nM
Beside the measured number, compound 3's estimate is 6.9-fold (0.84 log units) above it; measured number below the stated range.
By their numbers in this assay, from the lowest: compound 3; then compounds 1 and 2 (each within the scatter of the next).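

In this assay the aromatic carbon that carries 4-cyanobenzyl in compound 1 proves to be a place where the number can move, as cyclohexyl there gives a 6.6-fold lower number from compound 1 to compound 3 (0.82 log units; beyond the scatter) and so less compound is needed for the effect. The only earlier step, at a saturated chain carbon bound to an amine nitrogen, stayed within the scatter, so this is the first exchange among these compounds to go beyond it. Nothing measured here accounts for the shift.

The exchange alters the ring type, the size of the group and the nitrile all at once, so a plain benzyl or a phenyl group at this carbon would be needed to separate them. From the compounds shown here alone, whether cyclohexyl has the same effect alongside the furan-2-yl group of compound 2 also remains open.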